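The source may hold more compounds than are shown below. What is called first, only, known or untested is meant among the compounds shown, and "the series" means these compounds.

Three compounds share one core and differ only in the aryl group on the sulfonamide nitrogen. Compound 1 `Cc1cccc(NS(=O)(=O)c2ccc(N3CCNC3=O)cc2)c1` gives 69 nM in a functional assay on M21 cells (Homo sapiens) for antiproliferative activity, read by sulforhodamine B assay, with a stated time of 48 h; on this read-out higher numbers stand for weaker inhibition and lower numbers for stronger inhibition; compound 3 `Cc1ccc(NS(=O)(=O)c2ccc(N3CCNC3=O)cc2)cc1C` gives 94 nM; compound 2 `O=C1NCCN1c1ccc(S(=O)(=O)Nc2ccc(F)cc2)cc1` gives 230 nM. Compound 2 therefore has the highest number of the three, that is the weakest inhibition, with a 3.3-fold higher number from compound 1 to compound 2 (0.52 log units; beyond the scatter) and a 2.4-fold lower number from compound 2 to compound 3 (0.39 log units; beyond the scatter), both modest but beyond the scatter, while compound 1 and compound 3 lie within the scatter of each other a 1.4-fold higher number from compound 1 to compound 3 (0.13 log units; within the scatter).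

Compound 4 `CCCCOc1ccc(NS(=O)(=O)c2ccc(N3CCNC3=O)cc2)cc1` is the next variation, and it differs from compound 2 by butoxy in place of fluoro on an aromatic carbon. The two measured steps that bear on this one both start or end at compound 2 and both swap the fluoro-bearing ring for a methyl-bearing ring; both move the number down by a modest amount. Among the compounds with values here, no measured step exchanges fluoro for butoxy or any other chain, so the closest guidance is that leaving the fluoro-bearing ring has so far lowered the number modestly. On that basis a modest lowering is expected in this assay, a 1.9-fold lower number from compound 2 to compound 4 (0.28 log units; within the scatter), though the size is uncertain. Compound 4 is estimated at 120 nM, with a range from 45 nM to 320 nM.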

Compound 4, half-maximal inhibitory concentration: 580 nM
For compound 4 the middle estimate is 4.8-fold (0.68 log units) below the measured one; the measured number lies above the stated range.
By their numbers in this assay, from the lowest: compounds 1 and 3 (each within the scatter of the next); then compound 2; then compound 4.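

In this assay, within the data shown here, swapping fluoro for butoxy at this spot, para to a large group, gives a 2.5-fold higher number from compound 2 to compound 4 (0.40 log units; beyond the scatter) and so weaker inhibition, the first change in this set to move the number up from compound 2. Among these compounds, the only step so far that starts at compound 2 went the other way (a 2.4-fold lower number from compound 2 to compound 3 (0.39 log units; beyond the scatter)), so leaving the fluoro-bearing ring does not lower the number in itself, and the direction depends on what takes its place. Nothing available here explains why the butoxy compound gives the higher number.

From the compounds shown here alone, it stays open whether the rise follows the length of the chain, which shorter chains such as methoxy or ethoxy would test, or the oxygen that joins the chain to the ring, which a plain pentyl chain made of carbon alone would separate from chain length. How an amine or a carboxylic acid at this same spot would compare with fluoro and butoxy is also unknown.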